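Fluoro for chloro on a shared core

The source may hold more compounds than are shown below. What is called first, only, known or untested is meant among the compounds shown, and "the series" means these compounds.

Compound 1 `Cc1nc(N)nc2c1c(-c1ccc3oc(N)nc3c1)nn2C(C)C` and compound 2 `CC(C)n1nc(-c2ccc3oc(N)nc3c2)c2c(Cl)nc(N)nc21` share a core. In an ADME assay on microsomes from liver (Homo sapiens) for metabolic stability, read by LC-MS, with a stated time of 15 min, tested at 1 uM, in the presence of a further agent that is not named here (on this read-out lower numbers stand for a less stable compound and higher numbers for a more stable compound), compound 1 gives > 95%, which is a limit of the assay rather than a number. In this assay compound 2 gives 92%, the only plain number shown. Among the compounds with values here, the single measured step, a number at least 3 percentage points lower from compound 1 to compound 2 (that floor lies within the scatter), lies within the scatter, and the only evidence bearing on it is the limit of > 95% in this assay, at which 1 of the 2 values shown sits. Compound 3 `CC(C)n1nc(-c2ccc3oc(N)nc3c2)c2c(F)nc(N)nc21` differs from compound 2 by fluoro in place of chloro on an aromatic carbon. Within the data shown here, because the one halogen step a number at least 3 percentage points lower from compound 1 to compound 2 (that floor lies within the scatter) stayed within the scatter, no change beyond the scatter is expected in this assay. Compound 3 is expected at 92%, between 82% and 98%. The expected step is no change at the digits printed from compound 2 to compound 3 (within the scatter).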

Compound 3, percent of the compound remaining: 83%
The estimate for compound 3 lay 9 percentage points above the measured number; the measured number falls inside the stated range.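

In this assay, fluoro in place of chloro gives a number 9 percentage points lower from compound 2 to compound 3 (within the scatter), so this measurement does not separate the two halogens on this aromatic carbon. Fluoro in place of methyl on the same carbon gives a number at least 12 percentage points lower from compound 1 to compound 3 (beyond the scatter), the first step at this position shown to pass the scatter. Compound 1 stands at a limit of the assay, so that step is only a floor: the limit of > 95% in this assay, at which 1 of the 3 values shown sits.

From the compounds shown here alone, what an amine or a methoxy group on this carbon would give remains open. Going by these compounds, the full size of the step from the methyl compound also remains open.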